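Bromo for Chloro on the Benzyl Ring of Compound 3

The source may hold more compounds than are shown below. What is called first, only, known or untested is meant among the compounds shown, and "the series" means these compounds.

Measured compounds in an ADME assay on CHO-K1 cells (Cricetulus griseus) for cytotoxicity, read by MTT assay, with a stated time of 24 h; on this read-out lower numbers stand for stronger inhibition and higher numbers for weaker inhibition:
Compound 1 `O=[N+]([O-])c1cc(Sc2nnnn2C2CCCCC2)cc([N+](=O)[O-])c1` gives 153000 nM
Compound 2 `Cc1ccc(Cn2nnc(-c3cc([N+](=O)[O-])cc([N+](=O)[O-])c3)n2)cc1` gives 200000 nM
Compound 3 `O=[N+]([O-])c1cc(-c2nnn(Cc3ccc(Cl)cc3)n2)cc([N+](=O)[O-])c1` gives 170000 nM

Compound 3 sits within the usual scatter of both compound 1 and compound 2 in this assay, so the three numbers cannot be told apart. Among the measured compounds shown here, the only single-point step among them, a 1.2-fold lower number from compound 2 to compound 3 (0.07 log units; within the scatter), stayed within the scatter. Compound 4 `O=[N+]([O-])c1cc(-c2nnn(Cc3ccc(Br)cc3)n2)cc([N+](=O)[O-])c1` differs from compound 3 by bromo in place of chloro on an aromatic carbon. For the measured compounds named here, this swap of one halogen for another on the same aromatic carbon has no direct precedent among the measured compounds; the nearest comparison is the step from compound 2 to compound 3, which was flat. Compound 4 is therefore expected to stay close to compound 3, with an estimated no change at the digits printed from compound 3 to compound 4 (within the scatter) and a value of about 170000 nM, in the range 85000 nM to 340000 nM.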

Compound 4, half-maximal inhibitory concentration: 55000 nM
Estimate against measurement, compound 4: 3.1-fold (0.49 log units) above; measured number below the stated range.
By their numbers in this assay, from the lowest: compound 4; then compounds 1, 3 and 2 (each within the scatter of the next).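

In this assay this aromatic carbon proved responsive to the group it carries: going from 4-chlorobenzyl to 4-bromobenzyl gives a 3.1-fold lower number from compound 3 to compound 4 (0.49 log units; beyond the scatter) and bromo in place of methyl gives a 3.6-fold lower number from compound 2 to compound 4 (0.56 log units; beyond the scatter) even though chloro in place of methyl stayed within the scatter. Chloro and bromo are therefore not interchangeable at this carbon, and bromo is the first group here to separate from the others. No measurement shown accounts for this difference.

On these data alone, whether the trend continues to iodo remains open. So does how an amine or a carboxylic acid on this carbon would read.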